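Swapping a Chlorophenyl for a Methoxyphenyl on Two Cores

The compounds below may be only part of what the source reports. "The series", "measured", "known", "first", "only" and "open" are said of these compounds alone.

Compound 2 `COc1cc2c(Oc3ccc(NC(=O)c4cc(-c5cccc(Cl)c5)nc5ccccc45)cc3F)ccnc2cc1OCCCN1CCCCC1` carries a 3-chlorophenyl group on its core. In a functional assay on NCI-H460 cells (Homo sapiens) for cytotoxicity, read by MTT assay, with a stated time of 72 h (on this read-out higher numbers stand for weaker inhibition and lower numbers for stronger inhibition), compound 2 gives 11 nM. Compound 1 `COc1ccc(-c2cc(C(=O)Nc3ccc(Oc4ccnc5cc(OCCCN6CCCCC6)c(OC)cc45)c(F)c3)c3ccccc3n2)cc1` is the same molecule except for one exchange at that position: 4-methoxyphenyl in place of 3-chlorophenyl on an aromatic carbon. In this assay compound 1 gives 290 nM, so the exchange produced a large step toward weaker inhibition: a 26-fold higher number from compound 2 to compound 1 (1.42 log units; beyond the scatter).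

Compound 3 `COc1cc2c(Oc3ccc(NC(=O)c4cc(-c5cccc(Cl)c5)nc5ccc(F)cc45)cc3F)ccnc2cc1OCCCN1CCCC1` keeps the 3-chlorophenyl group but sits on a different core; the difference between the two cores is not broken down here. In this assay compound 3 gives 72 nM, which lies between the other two measured numbers. Compound 4 `COc1ccc(-c2cc(C(=O)Nc3ccc(Oc4ccnc5cc(OCCCN6CCCC6)c(OC)cc45)c(F)c3)c3cc(F)ccc3n2)cc1` has not been measured yet. It differs from compound 3 by exactly the change already seen: 4-methoxyphenyl in place of 3-chlorophenyl on an aromatic carbon. The surroundings of the exchanged group are described in the same words for both pairs, so the change is the same, not merely the same kind.

Among the measured compounds shown here, with only one precedent, the expectation rests on that single step. Compound 4 is expected to move by about a 21-fold higher number from compound 3 to compound 4 (1.32 log units; beyond the scatter), because the earlier exchange gave a 26-fold higher number from compound 2 to compound 1 (1.42 log units; beyond the scatter) and nothing in the data suggests the new core should respond differently. Compound 4 is therefore estimated at roughly 1500 nM, with a likely range from 450 nM to 5000 nM, allowing for the possibility that the step is smaller on this core.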

Compound 4, half-maximal inhibitory concentration: 250 nM
For compound 4 the middle estimate is 6.0-fold (0.78 log units) above the measured one, and the stated range ends above it.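

In this assay the exchange of 3-chlorophenyl for 4-methoxyphenyl again points toward weaker inhibition on the second core, with a 3.5-fold higher number from compound 3 to compound 4 (0.54 log units; beyond the scatter). So the direction of the change carried over in the one further case available, but its size did not, and the gap between the two steps is larger than repeated measurements would explain: the same change on two cores in this assay, a 26-fold higher number (1.42 log units; beyond the scatter) from compound 2 to compound 1 and a 3.5-fold higher number (0.54 log units; beyond the scatter) from compound 3 to compound 4, 7.6-fold (0.88 log units) apart, beyond the scatter of two such steps. A large penalty on one core therefore did not predict an equally large one on the other, yet these two pairs cannot show which of the differences between the cores alters the step, or why, and they give no rule for any further core.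

The exchange also combines two changes, a different group and a different place on the phenyl ring, and a 4-chlorophenyl or 3-methoxyphenyl group on each core would be needed to separate them. As far as these compounds go, it also remains open whether an amine on the same phenyl ring, or a third core, would follow the same direction, and how large any such step would be.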